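Chloro for methyl: working notes on three measured compounds

The source may report more compounds than this note shows. Statements on the series, on what has been measured and on what is new or still open speak of the compounds shown alone.

Measured so far:
- Compound 1, `Cc1cc(-n2cc(C(=O)Nc3cc(F)cc(F)c3)c(=O)c3ccc(N(C)C)nc32)ccc1OCCCCCCC[N+]12CCN(CC1)CC2`, in an assay on LX2 cells for inhibition of COL1A1 promoter (Homo sapiens), read by a luciferase reporter, with a stated time of 24 h, tested at 50 uM (a lower number here means a weaker effect, a higher number a stronger effect of the compound at the concentration tested), gives 20.8%.
- Compound 2, `CN(C)c1ccc2c(=O)c(C(=O)Nc3cc(F)cc(F)c3)cn(-c3ccc(OCCCCCCC[N+]45CCN(CC4)CC5)c(Cl)c3)c2n1`, in this assay gives 20.5%.
- Compound 3, `Cc1ccc(-n2cc(C(=O)Nc3cc(F)cc(F)c3)c(=O)c3ccc(N(C)C)nc32)cc1OCCCCCCC[N+]1(C)CCCCC1`, in this assay gives 45.1%.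

Compounds 1 and 2 differ in one place: chloro in place of methyl on an aromatic carbon. The step is a number 0.3 percentage points lower from compound 1 to compound 2 (within the scatter). Compound 3 stands highest of the three, and its gaps to compound 1 and to compound 2 are both beyond the scatter. The difference between the core of compound 1 and the core of compound 3 is not broken down here.

Compound 4, `CN(C)c1ccc2c(=O)c(C(=O)Nc3cc(F)cc(F)c3)cn(-c3ccc(Cl)c(OCCCCCCC[N+]4(C)CCCCC4)c3)c2n1`, is not yet measured. It differs from compound 3 by chloro in place of methyl on an aromatic carbon. Around the place this is not identical to the change from compound 1 to compound 2: there the ring carbon was meta to a large group, here it is para to a large group, so it is the same kind of change rather than the same change.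

The expectation for compound 4 in this assay rests on compound 3 at 45.1% and on the earlier step of a number 0.3 percentage points lower from compound 1 to compound 2 (within the scatter), which lay within the scatter. The step expected from compound 3 to compound 4 is a number 2.1 percentage points lower from compound 3 to compound 4 (within the scatter). Compound 4 is estimated at 43%, between 28% and 58%.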

Compound 4, a percentage reported as inhibition, at one concentration (the size of the read-out at that concentration, not a potency): 90.5%
For compound 4 the middle estimate is 47.5 percentage points below the measured one; the measured number lies above the stated range.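

In this assay, chloro in place of methyl on an aromatic carbon gives a number 45.4 percentage points higher from compound 3 to compound 4 (beyond the scatter), so on the core of compound 3 this change is far from neutral. Carried from one core to the other, the same kind of change does not give the same result: the same change on two cores in this assay, a number 0.3 percentage points lower (within the scatter) from compound 1 to compound 2 and a number 45.4 percentage points higher (beyond the scatter) from compound 3 to compound 4, 45.7 percentage points apart, beyond the scatter of two such steps This shows that the size of the step on one core cannot be carried over to the other in this series, but it does not show which difference sets the two steps apart: the place of the change around the ring and the rest of each core vary together, and two pairs give no general rule.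

Open, going by these compounds, is whether the large rise is specific to chloro or would also come with fluoro, bromo or methoxy on the same aromatic carbon. Going by these compounds alone, also open is whether the step would hold with a shorter or longer chain in place of the one carried by compound 4.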